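Dichlorobenzyl in place of the aminopyridinyl group of compound 1

A few compounds are considered here, and "the series" means these few. Any claim that something is new, unique, unknown or untested is made for them only; others in the source may bear on it.

Compound 1 `C[C@H](NC(=O)C(=O)Nc1cccnc1N(C)C)C(=O)N[C@@H](CC(=O)O)C(=O)COc1c(F)c(F)cc(F)c1F` gives 27 nM in a functional assay on Jurkat cells (Homo sapiens) (on this read-out lower numbers stand for stronger inhibition and higher numbers for weaker inhibition), the lowest of the two numbers measured in the series. Compound 2 `C[C@H](NC(=O)C(=O)NCc1ccc(F)cc1)C(=O)N[C@@H](CC(=O)O)C(=O)COc1c(F)c(F)cc(F)c1F` gives 197 nM in this assay, and the step between them is a 7.3-fold higher number from compound 1 to compound 2 (0.86 log units; beyond the scatter). Compound 3 `Cc1ccc(CNC(=O)C(=O)N[C@@H](C)C(=O)N[C@@H](CC(=O)O)C(=O)COc2c(F)c(F)cc(F)c2F)cc1C` is reported only as a limit of the assay, > 10000 nM in this assay (the limit of > 10000 nM in this assay, at which 1 of the 3 values shown sits). Read against that limit, the steps are an at least 370-fold higher number from compound 1 to compound 3 (2.56 log units; beyond the scatter) and an at least 50-fold higher number from compound 2 to compound 3 (1.70 log units; beyond the scatter).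

Compound 4 `C[C@H](NC(=O)C(=O)NCc1ccc(Cl)cc1Cl)C(=O)N[C@@H](CC(=O)O)C(=O)COc1c(F)c(F)cc(F)c1F` is not yet measured. Its change from compound 1 is 2,4-dichlorobenzyl in place of 2-(dimethylamino)pyridin-3-yl on an amide-type nitrogen. Both measured steps out of compound 1 replace the same 2-(dimethylamino)pyridin-3-yl on the amide-type nitrogen with a benzyl group carrying ring substituents, and both make the number worse, modestly for 4-fluorobenzyl and at least strongly for 3,4-dimethylbenzyl. A benzyl group bearing two chlorines is therefore expected to land between those two outcomes, nearer to compound 2, with a clearly higher number than compound 1 and an expected step of a 19-fold higher number from compound 1 to compound 4 (1.27 log units; beyond the scatter).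

Compound 4 is estimated to give about 500 nM in this assay, with an expected range from 120 nM to 3000 nM.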

Compound 4, half-maximal inhibitory concentration: 165 nM
Compound 4: the middle estimate sits 3.0-fold (0.48 log units) above what was measured, and the stated range covers the measured number.
By their numbers in this assay, from the lowest: compound 1; then compounds 4 and 2 (each within the scatter of the next). At a limit, above all of these: compound 3.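

Between 2,4-dichlorobenzyl and 4-fluorobenzyl on the amide-type nitrogen, this assay shows no separation, with a 1.2-fold lower number from compound 2 to compound 4 (0.08 log units; within the scatter). Leaving the 2-(dimethylamino)pyridin-3-yl of the core therefore has a modest cost with this second benzyl group as well, at a 6.1-fold higher number from compound 1 to compound 4 (0.79 log units; beyond the scatter), much like a 7.3-fold higher number from compound 1 to compound 2 (0.86 log units; beyond the scatter). Two ring substituents on a benzyl group do not by themselves bring the loss seen for compound 3, whose entry is a limit of the assay and not a number, so the step of an at least 60-fold lower number from compound 3 to compound 4 (1.78 log units; beyond the scatter) gives only a bound set by that limit: the limit of > 10000 nM in this assay, at which 1 of the 4 values shown sits.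

Between compound 3 and compound 4, both the substituents and their ring positions change, so the compounds shown do not tell whether methyl in place of chlorine or the 3,4-pattern in place of the 2,4-pattern decides the outcome, and a 3,4-dichlorobenzyl group would separate the two. They also leave open whether the lower number of compound 1 depends on the dimethylamino group, the pyridine nitrogen or the absence of a benzyl methylene, which a plain pyridin-3-yl or a pyridin-3-ylmethyl group could help to resolve.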